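Cyclopentyl replacing 4-fluorophenyl on the ring nitrogen

The source may report more compounds than this note shows. Statements on the series, on what has been measured and on what is new or still open speak of the compounds shown alone.

Working notes on the series. In an assay on Huh-7 cells for agonist activity at Bile acid receptor (Homo sapiens), read by a luciferase reporter (a lower number here means that less compound is needed, a higher number that more compound is needed for the effect), compound 2 `CC(C)c1onc(-c2c(Cl)cccc2Cl)c1COc1ccc(-c2nc3ccc(C(=O)O)cc3n2-c2ccc(F)cc2)cc1` gives 32.2 nM, the highest of the three numbers recorded. Compound 1 `CC(C)c1onc(-c2c(Cl)cccc2Cl)c1COc1ccc(-c2nc3ccc(C(=O)O)cc3n2CC(C)(C)C)cc1` gives 13 nM in this assay, and compound 3 `CCC(CC)n1c(-c2ccc(OCc3c(-c4c(Cl)cccc4Cl)noc3C(C)C)cc2Cl)nc2ccc(C(=O)O)cc21` gives 1.6 nM; compound 3 differs from compound 2 in more than one place, so only the two values themselves can be set side by side.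

The change to compound 4 `CC(C)c1onc(-c2c(Cl)cccc2Cl)c1COc1ccc(-c2nc3ccc(C(=O)O)cc3n2C2CCCC2)cc1` is cyclopentyl in place of 4-fluorophenyl on an aromatic nitrogen. For the measured compounds named here, the one measured step touching this position is a 2.5-fold higher number from compound 1 to compound 2 (0.39 log units; beyond the scatter), where the 4-fluorophenyl entered in place of neopentyl. Compound 4 takes the 4-fluorophenyl out again and puts a cyclopentyl there. Because a 2.5-fold higher number from compound 1 to compound 2 (0.39 log units; beyond the scatter) was modest and beyond the scatter, the return to a non-aromatic ring is expected to run the other way, towards a lower number of about the same size. For compound 4 in this assay the estimate is 12 nM, range 4 nM to 35 nM, meaning an expected step of a 2.7-fold lower number from compound 2 to compound 4 (0.43 log units; beyond the scatter).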

Compound 4, half-maximal effective concentration: 13.6 nM
For compound 4 the middle estimate is 1.1-fold (0.05 log units) below the measured one, and the stated range covers the measured number.
By their numbers in this assay, from the lowest: compound 3; then compounds 1 and 4 (each within the scatter of the next); then compound 2.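

In this assay, the 4-fluorophenyl on the aromatic nitrogen gives way to cyclopentyl with a 2.4-fold lower number from compound 2 to compound 4 (0.37 log units; beyond the scatter), so a second non-aromatic carbon group, after neopentyl, now gives a lower number than the 4-fluorophenyl on the same core. The two non-aromatic groups cannot be separated at this position, with a 1.0-fold higher number from compound 1 to compound 4 (0.02 log units; within the scatter), even though they differ in shape, one a ring and the other a branched chain. Nothing available gives a reason for either step.

As far as these compounds go, it remains open whether the higher number of compound 2 goes with the aromatic ring or with its fluorine, a question a plain phenyl on the same nitrogen would address. Also open, from the compounds shown here alone, is how a methyl, or a chain carrying an amine, would read at this position.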